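The compounds below may be only part of what the source reports. "The series", "measured", "known", "first", "only" and "open" are said of these compounds alone.

Measured compounds:
Compound 1, `O=c1[nH]cc(S(=O)(=O)Nc2cccc(-c3cn(-c4ccccc4Cl)nn3)c2)c(=O)[nH]1`, 3010 nM
Compound 2, `O=c1[nH]cc(S(=O)(=O)Nc2cccc(-c3cn(-c4cccc(Cl)c4)nn3)c2)c(=O)[nH]1`, 3950 nM
Compound 3, `O=c1[nH]cc(S(=O)(=O)Nc2ccc(-c3cn(-c4ccccc4Cl)nn3)cc2)c(=O)[nH]1`, 2680 nM

All three were tested in a functional assay on SGC-7901 cells (Homo sapiens) for antiproliferative activity, read by MTT assay, with a stated time of 24 h; on this read-out lower numbers stand for stronger inhibition and higher numbers for weaker inhibition. Compound 1 and compound 2 share one core and differ only in the group on the aromatic nitrogen of the five-membered ring; this change is 3-chlorophenyl in place of 2-chlorophenyl on an aromatic nitrogen, and it gave a 1.3-fold higher number from compound 1 to compound 2 (0.12 log units; within the scatter). Compound 3 carries the 2-chlorophenyl group of compound 1 on a core of its own; how that core differs from the core of compound 1 is not broken down here. In this assay compound 3 gives 2680 nM, and compound 1 gives 3010 nM, two numbers within the scatter of each other, so no order between them can be drawn.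

Compound 4, `O=c1[nH]cc(S(=O)(=O)Nc2ccc(-c3cn(-c4cccc(Cl)c4)nn3)cc2)c(=O)[nH]1`, has not yet been measured in this assay. It stands to compound 3 as compound 2 stands to compound 1: the change is 3-chlorophenyl in place of 2-chlorophenyl on an aromatic nitrogen, the same change at the same place, a 3-chlorophenyl group entering where a 2-chlorophenyl group leaves on the aromatic nitrogen. Among the measured compounds shown here, since the one earlier instance of this change, from compound 1 to compound 2, stayed within the scatter, a step of about the same size is expected for compound 4, namely a 1.3-fold higher number from compound 3 to compound 4 (0.12 log units; within the scatter), because a 1.3-fold higher number from compound 1 to compound 2 (0.12 log units; within the scatter) is the only guide available. On that basis compound 4 is estimated at 3500 nM, with a likely range from 1900 nM to 6500 nM.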

Compound 4, half-maximal inhibitory concentration: 2460 nM
Beside the measured number, compound 4's estimate is 1.4-fold (0.15 log units) above it; the measured number falls inside the stated range.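

In this assay, the same exchange on the second core gave a 1.1-fold lower number from compound 3 to compound 4 (0.04 log units; within the scatter), and set beside the earlier step, the two do not differ: the same change on two cores in this assay, a 1.3-fold higher number (0.12 log units; within the scatter) from compound 1 to compound 2 and a 1.1-fold lower number (0.04 log units; within the scatter) from compound 3 to compound 4, 1.4-fold (0.16 log units) apart, within the scatter of two such steps. On neither core did replacing 2-chlorophenyl with 3-chlorophenyl produce a step that stands out from the scatter, so the near-absence of a readable step carries from one core to the other in these two pairs. Among the compounds shown here, this does not show that the change has an effect of constant size or direction, since the two steps cannot be told from no step at all, and a pair of cores is too few to set a rule for the series.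

The compounds shown carry only chlorophenyl groups on the aromatic nitrogen, so it remains open whether an unsubstituted phenyl, a methoxyphenyl, a benzyl group or a short alkyl chain there would shift the number beyond the scatter. Also open, as far as these compounds go, is whether an amine or a carboxylic acid on that phenyl ring would do so, and whether the two cores would then respond alike.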